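The compounds below may be only part of what the source reports. "The series", "measured", "known", "first", "only" and "open" are said of these compounds alone.

Working notes on the series. Compound 1 `O[C@@H]1c2cc(OCc3ccc4ccccc4n3)ccc2OC[C@H]1Cc1cccnc1` gives 1000 nM in an assay on isolated protein for inhibition of cysteinyl leukotriene receptor 1 (Cavia porcellus); a lower number here means a stronger inhibitor, a higher number a weaker inhibitor. Compound 2 `CC(Oc1ccc2c(c1)OC[C@H](Cc1ccccn1)[C@@H]2O)c1ccc2ccccc2n1` returns only a limit of the assay in this assay, > 50000 nM, which marks it as the weaker binder of the two; the evidence on this point is the limit of > 50000 nM in this assay, at which 1 of the 2 values shown sits. Compound 3 `CC(Oc1ccc2c(c1)OC[C@@H](Cc1ccccn1)[C@@H]2O)c1ccc2ccccc2n1` differs from compound 2 in one place: the two compounds have the same atoms and bonds; at least one stereo element is drawn with a configuration in one of them and without one in the other: 1 of 3 stereo elements differ; a stereocentre at a saturated ring carbon is drawn S in compound 2 and R in compound 3, a stereocentre at a saturated ring carbon being drawn S in compound 2 and R in compound 3. Among the compounds with values here, no measured pair tells how large such a change runs here, so the expected step from compound 2 to compound 3 is an at least 5.0-fold lower number from compound 2 to compound 3 (0.69 log units; beyond the scatter), a gain in binding that is uncertain in size. For compound 3 the estimate in this assay is 10000 nM, with a range from 1000 nM to 50000 nM.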

Compound 3, inhibition constant: > 50000 nM
Compound 3: only a limit was reported (the forecaster's own chance of this, stated with the estimate: 40%); middle value at least 5.0-fold (0.69 log units) from the limit.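

Within the data shown here, compound 2 and compound 3 both return only a limit of the assay in this assay, so no step between them can be read. The compounds shown leave open whether the stereocentre at the saturated ring carbon affects binding at all.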